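The source may report more compounds than this note shows. Statements on the series, on what has been measured and on what is new or still open speak of the compounds shown alone.

Compound 1 `CCCCOc1cccc(C(=O)Nc2cccc(C(=O)O)c2)c1`: 3150 nM
Compound 2 `CCCCOc1ccc(C(=O)Nc2cccc(C(=O)O)c2)cc1`: 105 nM
Compound 3 `O=C(O)c1cccc(NC(=O)c2ccc(OCc3cccc(-c4ccccc4)c3)cc2)c1`: 319 nM

In an assay on isolated protein for agonist activity at Bile acid receptor (Homo sapiens), read by TR-FRET, with a stated time of 3 h, in the absence of a further agent (a lower number here means that less compound is needed, a higher number that more compound is needed for the effect), compound 2 gives the lowest of the three numbers. Compound 3 stands nearest to it, with a higher number beyond the scatter, and compound 1 stands furthest, with a higher number far beyond the scatter. The step to compound 4 `CO/N=C(/COc1ccc(C(=O)Nc2cccc(C(=O)O)c2)cc1)c1ccccc1` alters the chain on the oxygen of compound 2: a group of 10 heavy atoms (8 carbon, 1 nitrogen, 1 oxygen; one six-membered aromatic ring of carbon only) in place of a group of 3 heavy atoms (3 carbon; no ring), on a saturated chain carbon bound to an oxygen on an aromatic ring. Within the data shown here, no measured pair in this set differs in exactly one place, so no step is available to set the size of this change. What can be said is that compound 3, which also carries a group with an aromatic ring on that oxygen, gives 319 nM in this assay, whereas compound 2 gives 105 nM. On this basis a moderate rise in the number is expected, without a firm size. For compound 4 the expected step is a 2.4-fold higher number from compound 2 to compound 4 (0.38 log units; beyond the scatter). Compound 4 is therefore estimated at 250 nM, within a range from 60 nM to 1000 nM.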

Compound 4, half-maximal effective concentration: > 10000 nM
Compound 4 gave a limit, no number (the forecaster's own chance of this, stated with the estimate: 5%); at least 40-fold (1.60 log units) between middle value and limit.
By their numbers in this assay, from the lowest: compound 2; then compound 3; then compound 1. At a limit, above all of these: compound 4.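

In this assay compound 4 gives > 10000 nM, a limit of the assay and not a number: the limit of > 10000 nM in this assay, at which 1 of the 4 values shown sits. Among these compounds, with the propyl replaced on the saturated chain carbon bound to an oxygen on an aromatic ring, the change brings an at least 95-fold higher number from compound 2 to compound 4 (1.97 log units; beyond the scatter), which shows that a change at this place alone can take the read-out out of the measurable range, something the earlier compounds did not reveal. An aromatic ring in the group at this place does not by itself settle the outcome, as compound 3, which also carries one there, gives 319 nM.

The compounds shown do not separate the contributions of the ring, the double bond and the nitrogen and oxygen of the entering group. Nor do they show how a plain benzyl group or a longer alkyl chain would read at this place.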